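Ubiquitin hydrolase 7 series: replacing the dimethylpiperazinylmethyl group

This account rests on a few compounds, and the source may have more. Where it says the series, first, only, none or still open, it means among the compounds named here.

Of the compounds shown here, three on the shared core have been measured in an assay on RKO cells for inhibition of ubiquitin carboxyl-terminal hydrolase 7 (Homo sapiens), read by a luciferase reporter, with a stated time of 18 h; on this read-out higher numbers stand for an effect only at larger amounts of compound and lower numbers for an effect already at smaller amounts. Compound 1 `Cc1cc(Cl)cc(-c2ccnc3cc(CN4C(=O)CCC4=O)sc23)c1O[C@H]1C[C@H](N)C1` gives 150 nM. Compound 2 `Cc1cc(Cl)cc(-c2ccnc3cc(CN4C(=O)CCC4=O)sc23)c1CN1CCNC[C@@H]1C` gives 280 nM. Compound 3 `Cc1cc(Cl)cc(-c2ccnc3cc(CN4C(=O)CCC4=O)sc23)c1CN1[C@@H](C)CNC[C@@H]1C` gives 60 nM, the lowest of the three numbers; one step is a 2.5-fold lower number from compound 1 to compound 3 (0.40 log units; beyond the scatter), and another is a 4.7-fold lower number from compound 2 to compound 3 (0.67 log units; beyond the scatter), so compound 3 is set apart from both on this read-out.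

Compound 4 `Cc1cc(Cl)cc(-c2ccnc3cc(CN4C(=O)CCC4=O)sc23)c1OC1CCNCC1` is not yet measured. The change from compound 3 is (piperidin-4-yl)oxy in place of (2,6-dimethylpiperazin-1-yl)methyl on an aromatic carbon. For the measured compounds named here, two measured steps bear on it. The step from compound 2 to compound 3 shows what the methyl groups on the ring carbons contributed, and compound 4 carries none of them. The step from compound 1 to compound 3 shows the shift from an ether-linked amine to the methyl-linked piperazine, and compound 4 returns to an ether-linked cyclic amine, which places it nearer to compound 1 than to compound 3. A modest rise in the number for compound 4 is therefore expected, estimated as a 2.5-fold higher number from compound 3 to compound 4 (0.40 log units; beyond the scatter), landing close to where compound 1 stands. Compound 4 is expected to give about 150 nM in this assay, within a range of 60 nM to 400 nM.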

Compound 4, half-maximal effective concentration: 400 nM
Compound 4: the middle estimate sits 2.7-fold (0.43 log units) below what was measured; the range from low to high includes it.
By their numbers in this assay, from the lowest: compound 3; then compounds 1, 2 and 4 (each within the scatter of the next, the first and the last beyond it).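

In this assay, for the compounds shown here, the position on the aromatic carbon para to the chloro group proves sensitive to the loss of (2,6-dimethylpiperazin-1-yl)methyl: (piperidin-4-yl)oxy gives a 6.7-fold higher number from compound 3 to compound 4 (0.82 log units; beyond the scatter), the largest step so far, so the low number of compound 3 is not kept by this ether-linked cyclic amine. Against the (2-methylpiperazin-1-yl)methyl group, the same ether gives a 1.4-fold higher number from compound 2 to compound 4 (0.15 log units; within the scatter), so these two different linkers cannot be told apart on this read-out, and compound 3 remains set apart from both. Going by these compounds alone, with the ether oxygen held constant, the group on it also matters for the first time, since piperidin-4-yl in place of 3-aminocyclobutyl gives a 2.7-fold higher number from compound 1 to compound 4 (0.43 log units; beyond the scatter), which shows that the ether link alone does not fix the number.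

The compounds shown leave open whether a 2,6-dimethylpiperidin-4-yl group on the same oxygen would produce a shift like that of the added ring methyl in a 4.7-fold lower number from compound 2 to compound 3 (0.67 log units; beyond the scatter), and how a morpholin-4-ylmethyl group would read in this place. Nothing available here offers an explanation for any of these shifts.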